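A Biaryl Replacement on the Fused Core of Compound 2

This account rests on a few compounds, and the source may have more. Where it says the series, first, only, none or still open, it means among the compounds named here.

Of the compounds shown here, three have been measured in an ADME assay on HepG2 cells (Homo sapiens) for cytotoxicity, read by luminescence, CellTiter-Glo and ATP content, with a stated time of 72 h; on this read-out higher numbers stand for an effect only at larger amounts of compound and lower numbers for an effect already at smaller amounts. Compound 2 `COc1ccc(F)cc1CNCCCNc1ccnc2cc(Cc3ccc(F)cc3Cl)ccc12` gives 2460 nM, the lowest of the three numbers; compound 3 `Fc1ccc(Cc2ccc3c(NCCCNCc4ccco4)ccnc3c2)c(Cl)c1` gives 5730 nM, and compound 1 `COc1cccc(CNCCCNc2ccnc3cc(Oc4ccccc4)ccc23)c1O` gives 6800 nM. For the measured compounds named here, the only step between compounds differing in one place is a 2.3-fold higher number from compound 2 to compound 3 (0.37 log units; beyond the scatter), and it concerns the chain end away from the fused system. Compound 4 `COc1ccc(F)cc1CNCCCNc1ccnc2cc(-c3ccc(C(C)(C)C)cc3)ccc12` differs from compound 2 by 4-(tert-butyl)phenyl in place of 2-chloro-4-fluorobenzyl on an aromatic carbon. Going by the values given here, no measured step touches this position, so the change has no direct precedent here, and the three measured values together span only a modest range. Compound 4 is therefore expected to show little movement, a 1.3-fold higher number from compound 2 to compound 4 (0.11 log units; within the scatter), with its value estimated at 3200 nM in a range from 1200 nM to 8500 nM.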

Compound 4, half-maximal effective concentration: 620 nM
The estimate for compound 4 lay 5.2-fold (0.71 log units) above the measured number; the whole stated range lies above it.
By their numbers in this assay, from the lowest: compound 4; then compound 2; then compounds 3 and 1 (each within the scatter of the next).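

For the compounds shown here, the step of a 4.0-fold lower number from compound 2 to compound 4 (0.60 log units; beyond the scatter) is the first at this position on the shared core, and it lies beyond the scatter, so the number responds to a change here as well as at the chain end. The change replaces 2-chloro-4-fluorobenzyl with a directly attached ring and also alters the ring's substituents. No evidence here explains why the number fell. The compounds shown do not separate these two alterations, leaving open how a 4-(tert-butyl)benzyl group or an unsubstituted phenyl would read. Also open, on these data alone, is whether furan-2-yl at the chain end would shift the number of compound 4 as it did for compound 2.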